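The compounds below may be only part of what the source reports. "The series", "measured", "known", "first", "only" and "open" are said of these compounds alone.

Compound 3 `CO[C@H]1CC=C2CCN(C)[C@H]2C1` gives the lowest of the two numbers shown in an assay on HEK293 cells for displacement of a labelled ligand from Neuronal acetylcholine receptor; alpha3/beta4 (Rattus norvegicus), with a stated time of 4 h (a lower number here means a stronger inhibitor, a higher number a weaker inhibitor), at 100000 nM. Its nearest neighbour is compound 2 `COCCO[C@H]1CC[C@H]2CCN(C)[C@H]2C1`, which in this assay gives 300000 nM, a gap beyond the scatter. Compound 1 `CO[C@H]1CC[C@H]2CCN(C)[C@H]2C1` reaches only a limit of the assay, > 300000 nM. The unmeasured compound 4 `COCCO[C@H]1CC=C2CCN(C)[C@H]2C1` differs from compound 3 by methoxymethyl in place of hydrogen on a saturated chain carbon bound to an oxygen on a saturated carbon. Among the measured compounds shown here, the one measured step of the same kind, a number no higher from compound 1 to compound 2 (the limit leaves the size open), is read against (the limit of > 300000 nM in this assay, at which 1 of the 3 values shown sits), so its size stays open. On that evidence the step of no change at the digits printed from compound 3 to compound 4 (within the scatter) is expected to be small, with no clear direction beyond the scatter. Compound 4 is therefore estimated at 100000 nM, within a range of 30000 nM to 400000 nM.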

Compound 4, inhibition constant: > 300000 nM
Compound 4: a limit, no number; the forecaster's own chance of this, stated with the estimate: 20%; at least 3.0-fold (0.47 log units) between middle value and limit.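

In this assay, the methoxymethyl change on the core of compound 3 gives an at least 3.0-fold higher number from compound 3 to compound 4 (0.47 log units; beyond the scatter), so at this position the longer chain weakens the compound on that core. The change does not carry over at one size from one core to the other: the same change on two cores in this assay, a number no higher (the limit leaves the size open) from compound 1 to compound 2 and an at least 3.0-fold higher number (0.47 log units; beyond the scatter) from compound 3 to compound 4, at least 3.0-fold (0.47 log units) apart, beyond the scatter of two such steps Compound 4 also sits at a limit, so this step is bounded on one side only: the limit of > 300000 nM in this assay, at which 2 of the 4 values shown sit.

Going by these compounds, how far compound 4 lies past that limit stays open. On these data alone, whether an amine or a carboxylic acid in place of the 2-methoxyethoxy group would give a lower number also stays open.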